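Swapping chloro for fluoro on the benzyl arm of compound 1

The source may hold more compounds than are shown below. What is called first, only, known or untested is meant among the compounds shown, and "the series" means these compounds.

Measured compounds:
- compound 1, `COc1ccc(/C=C2\CN(C(=S)SCc3cn(Cc4ccccc4Cl)nn3)C/C(=C\c3ccc(OC)cc3)C2=O)cc1` — in a functional assay on MCF7 cells (Homo sapiens) for cytotoxicity, read by MTT assay, with a stated time of 24 h (on this read-out lower numbers stand for stronger inhibition and higher numbers for weaker inhibition), compound 1 gives > 100000 nM, which is a limit of the assay and not a number
- compound 2, `Cc1ccc(/C=C2\CN(Cc3cn(Cc4cccc(Cl)c4)nn3)C/C(=C\c3ccc(C)cc3)C2=O)cc1` — compound 2 gives 10000 nM
- compound 3, `O=C1/C(=C/c2ccccc2F)CN(C(=S)SCc2cn(Cc3ccccc3F)nn2)C/C1=C\c1ccccc1F` — compound 3 gives 51600 nM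

Compound 1 stands at the upper edge of what this assay reports. Its result, (the limit of > 100000 nM in this assay, at which 1 of the 3 values shown sits), tells only that no half-maximal inhibition was reached within the tested range, and the values of compound 2 and compound 3 show that the other two analogues do return numbers, both far from strong inhibition.

The unmeasured analogue is compound 4, `COc1ccc(/C=C2\CN(C(=S)SCc3cn(Cc4ccccc4F)nn3)C/C(=C\c3ccc(OC)cc3)C2=O)cc1`. It differs from compound 1 in one place: fluoro in place of chloro on an aromatic carbon. The shared core with its two methoxy-bearing arms and the dithiocarbamate-linked triazole remains.

Going by the values given here, with no measured step between two compounds differing in one place, the size of this step can only be expected, not read. Compound 3, which carries fluoro on the same arm, gives 51600 nM, and that is the nearest point of comparison. Compound 4 is therefore estimated at 80000 nM, within 30000 nM to 200000 nM, meaning an expected step of an at least 1.2-fold lower number from compound 1 to compound 4 (0.09 log units; that floor lies within the scatter) that may well stay within the scatter and may again end as a limit.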

Compound 4, half-maximal inhibitory concentration: 79400 nM
The estimate for compound 4 lay 1.0-fold (0.00 log units) above the measured number; the measured number falls inside the stated range.
By their numbers in this assay, from the lowest: compound 2; then compounds 3 and 4 (each within the scatter of the next). At a limit, above all of these: compound 1.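

In this assay, fluoro in place of chloro on the ortho-substituted benzyl arm gives an at least 1.2-fold lower number from compound 1 to compound 4 (0.10 log units; that floor lies within the scatter). Going by these compounds alone, this is the first one-place comparison, and it shows that with the two methoxy-bearing arms kept, compound 4 returns a measured number with 2-fluorobenzyl on this arm. The true size of the step cannot be read, since its floor is all that is known and that floor does not clear the scatter, and the value of compound 1 is a limit: the limit of > 100000 nM in this assay, at which 1 of the 4 values shown sits.

The compounds shown leave open how an amine or a carboxylic acid at this aromatic carbon would read in this assay. They also leave open whether the same swap of chloro for fluoro would give a similar step on the arms of compound 2 or compound 3.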